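This account rests on a few compounds, and the source may have more. Where it says the series, first, only, none or still open, it means among the compounds named here.

Compound 1 `C[C@@H](/N=c1\c(O)c(O)\c1=N/Cc1ccc(C#N)cc1)C(C)(C)C`, compound 2 `CCC(C)(C)/N=c1\c(O)c(O)\c1=N/Cc1c(C)cc(C)cc1C` and compound 3 `N#Cc1ccc(CNc2c(NCc3ccc(C#N)cc3)c(=O)c2=O)cc1` share one core and were tested in a functional assay for inhibition, with Rattus norvegicus as the target; a higher number here means a weaker inhibitor, a lower number a stronger inhibitor. Compound 1 gives 270 nM. Among the compounds with values here, compound 2 gives 310 nM, a number that lies within the scatter of the one for compound 1, so the two cannot be told apart. For compound 3 this assay reports only a limit, > 30000 nM, not a number. Compound 4 `CCC(C)(C)/N=c1\c(O)c(O)\c1=N/Cc1c(C)cc(C)cc1Cl` has not yet been measured in this assay. It differs from compound 2 by chloro in place of methyl on an aromatic carbon. Within the data shown here, no measured pair in this set shows a change of one group on that ring, so there is no recorded step to lean on. The expected step is a 1.0-fold lower number from compound 2 to compound 4 (0.01 log units; within the scatter), small enough to stay within the scatter in either direction. Compound 4 is therefore estimated at 300 nM, with a range from 120 nM to 800 nM.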

Compound 4, half-maximal inhibitory concentration: 200 nM
The estimate for compound 4 lay 1.5-fold (0.18 log units) above the measured number, and the stated range covers the measured number.
By their numbers in this assay, from the lowest: compounds 4, 1 and 2 (each within the scatter of the next). At a limit, above all of these: compound 3.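

Within the data shown here, compound 2 and compound 4 are the first pair here that changes a single group on this ring. In this assay, chloro in place of methyl, ortho to a large group, gives a 1.6-fold lower number from compound 2 to compound 4 (0.19 log units; within the scatter), so at this position the two groups cannot be told apart. Nothing available here bears on why the swap makes so little difference. Going by these compounds, whether an amine or a carboxylic acid at this position would give a step beyond the scatter remains open. So does whether chloro and methyl would also match on a different ring.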